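Ester variation on a triterpenoid core in MCF7 proliferation

The source may report more compounds than this note shows. Statements on the series, on what has been measured and on what is new or still open speak of the compounds shown alone.

Measured compounds:
- compound 1 `CC1=CC[C@H]2[C@H](CC[C@]2(C)O)C(C)(C)[C@@H]1CC[C@H]1[C@]2(C)CC[C@H](OC(=O)c3ccc(C)cc3)C(C)(C)O[C@H]2CC[C@@]1(C)O`: > 50000 nM
- compound 2 `CC1=CC[C@H]2[C@@H]1CC=C(C)[C@@H](CC[C@H]1[C@]3(C)CC[C@H](OC(=O)CCC(=O)O)C(C)(C)O[C@H]3CC[C@@]1(C)O)C2(C)C`: > 50000 nM

In a functional assay on MCF7 cells (Homo sapiens) for antiproliferative activity, read by MTT assay, with a stated time of 72 h (a higher number here means a weaker inhibitor, a lower number a stronger inhibitor), compound 1 gives > 50000 nM, which is a limit of the assay and not a number. For compound 2 the reading in this assay is also a limit, > 50000 nM. Compound 1 therefore stands at the limit of > 50000 nM in this assay, at which 2 of the 2 values shown sit, and nothing in the two readings separates it from compound 2; both are simply inactive up to the limit.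

Compound 3 `CC1=CC[C@H]2[C@H](CC[C@]2(C)O)C(C)(C)[C@@H]1CC[C@H]1[C@]2(C)CC[C@H](OC(=O)c3ccccc3[N+](=O)[O-])C(C)(C)O[C@H]2CC[C@@]1(C)O` differs from compound 1 at the ester only: 2-nitrophenyl in place of 4-methylphenyl on a carbonyl carbon. Within the data shown here, no measured pair here shows the effect of any such change, so the step from compound 1 to compound 3 in this assay can only be guessed; the expectation is no step beyond the scatter, and it is estimated as a step that the limit leaves unreadable from compound 1 to compound 3. With both measured compounds at the limit, compound 3 is expected to read at or near it as well, estimated at 60000 nM, within 20000 nM to 200000 nM, and most likely reported again only as a limit.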

Compound 3, half-maximal inhibitory concentration: 5200 nM
Beside the measured number, compound 3's estimate is 12-fold (1.06 log units) above it; measured number outside the range, below it.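

In this assay, the ester on the shared core proves to be a position where a single change gives a readable value: 2-nitrophenyl in place of 4-methylphenyl on a carbonyl carbon yields an at least 9.6-fold lower number from compound 1 to compound 3 (0.98 log units; beyond the scatter). This step lies beyond the scatter but gives only a bound on its true size, because compound 1 stands at a limit of the assay and not at a number: the limit of > 50000 nM in this assay, at which 2 of the 3 values shown sit. The six-membered aromatic ring of carbon stays in place through the change, while the heavy atoms go from 7 to 9 and the hydrogen-bond acceptors from 0 to 2, and this single pair does not show which of these differences, or the place of the substituent on the ring, carries the step.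

As far as these compounds go, whether the nitro group itself is needed remains open, as does how an amine or a chlorine on the same phenyl ring of the ester would read in this assay. Whether the step carries over to a core other than that of compound 1 also remains open, since the compounds shown contain no matching pair.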